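Amide variation at the shared core: cytotoxicity working notes

This account rests on a few compounds, and the source may have more. Where it says the series, first, only, none or still open, it means among the compounds named here.

Measured compounds:
compound 1, `C=CC1=C(C(=O)NCc2ccccc2)C(c2ccc(OC)cc2)OC1`, gives in a functional assay on HeLa cells (Homo sapiens) for cytotoxicity, read by MTT assay, with a stated time of 24 h (a higher number here means a weaker inhibitor, a lower number a stronger inhibitor), only the limit > 100000 nM.
compound 2, `C=CC1=C(C(=O)NC(C)(C)C)C(c2ccc(OC)cc2)OC1`, gives in this assay only the limit > 100000 nM.
compound 3, `C=CC1=C(C(=O)Nc2ccccc2)C(c2ccc(OC)cc2)OC1`, gives in this assay only the limit > 100000 nM.

For the measured compounds named here, compound 3 therefore stands at a limit of this assay, and the two other values shown for this set are limits as well; no compound of the set has a number inside the measured range. Compound 4, `C=CC1=C(C(=O)NCc2ccc(Cl)cc2)C(c2ccc(OC)cc2)OC1`, differs from compound 3 in one place: 4-chlorobenzyl in place of phenyl on an amide-type nitrogen.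

The measured steps at the amide-type nitrogen bear directly on this change, but each of them runs from one limit to another: a step that the two limits leave unreadable from compound 1 to compound 2, a step that the two limits leave unreadable from compound 1 to compound 3 and a step that the two limits leave unreadable from compound 2 to compound 3. None of them has a readable size or direction. Because (the limit of > 100000 nM in this assay, at which 3 of the 3 values shown sit), the replacement of one amide substituent by another has so far not moved any value into the readable range, whether the group was benzyl, tert-butyl or phenyl.

For compound 4 the expected step is accordingly a number no higher from compound 3 to compound 4 (the limit leaves the size open), which is to say no readable change is expected. Compound 4 is estimated at 100000 nM, with a range from 30000 nM to 300000 nM, the most likely outcome being once more a limit rather than a number.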

Compound 4, half-maximal inhibitory concentration: > 100000 nM
Compound 4: only a limit was reported; the forecaster's own chance of this, stated with the estimate: 85%; the middle value lies on the limit itself.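

Compound 4 in this assay again gives only a limit, > 100000 nM. Its steps from compound 1, compound 2 and compound 3 therefore cannot be read in size or direction. The compounds shown leave open whether any amide substituent on the shared core gives a number inside the measured range, and how these four compounds differ: the limit of > 100000 nM in this assay, at which 4 of the 4 values shown sit.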